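Chloro for trifluoromethyl in the pyrazolyl urea series

The source may report more compounds than this note shows. Statements on the series, on what has been measured and on what is new or still open speak of the compounds shown alone.

The three measured compounds share one core and are read in a functional assay on KM12 cells (Homo sapiens) for inhibition, read by sulforhodamine B assay, with a stated time of 48 h, tested at 10 uM; on this read-out higher numbers stand for a weaker effect at the one concentration tested and lower numbers for a stronger effect. Compound 1 `O=C(Nc1cccc(-n2cc(-c3ccncc3)c(-c3cc(O)cc(Cl)c3)n2)c1)Nc1ccc(Cl)c(C(F)(F)F)c1` gives 15.1%. Compound 2 `O=C(Nc1cccc(-n2cc(-c3ccncc3)c(-c3cc(O)cc(Cl)c3)n2)c1)Nc1ccc(Cl)c(Cl)c1` differs from compound 1 by chloro in place of trifluoromethyl on an aromatic carbon. Compound 2 gives 2.26%, a step of a number 12.8 percentage points lower from compound 1 to compound 2 (beyond the scatter). Compound 3 `COc1cc(Cl)cc(-c2nn(-c3cccc(NC(=O)Nc4ccc(Cl)c(C(F)(F)F)c4)c3)cc2-c2ccncc2)c1` differs from compound 1 by methyl in place of hydrogen on an oxygen on an aromatic ring. Compound 3 gives 9.1%; the step from compound 1 to compound 3 is a number 6 percentage points lower from compound 1 to compound 3 (within the scatter), so these two numbers are not told apart here. Among the compounds with values here, compound 2 and compound 3 have no step counted between them; their two values simply stand as given.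

Compound 4 `COc1cc(Cl)cc(-c2nn(-c3cccc(NC(=O)Nc4ccc(Cl)c(Cl)c4)c3)cc2-c2ccncc2)c1` is not yet measured. It differs from compound 3 by chloro in place of trifluoromethyl on an aromatic carbon, and the two cores differ by methyl in place of hydrogen on an oxygen on an aromatic ring. The place of the change in compound 3 reads word for word as in compound 1, so this is the same change as from compound 1 to compound 2, made on the core of compound 3 instead.

Within the data shown here, the expectation for compound 4 in this assay rests on the one earlier instance, and the number is estimated to move by a number 6.1 percentage points lower from compound 3 to compound 4 (within the scatter), a step taken to follow the modest lowering seen due to a number 12.8 percentage points lower from compound 1 to compound 2 (beyond the scatter). Since compound 3 already starts at a low number, the expected value for compound 4 is placed near the floor of the read-out, at 3%, with a plausible span from 0% to 12%.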

Compound 4, a percentage reported as activity, at one concentration (the size of the read-out at that concentration, not a potency): 14.4%
Compound 4: middle estimate off by 11.4 percentage points, on the low side; the measured number lies above the stated range.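

In this assay, chloro in place of trifluoromethyl on an aromatic carbon does not carry from the core of compound 1 to the core of compound 3, where the change reads as a number 5.3 percentage points higher from compound 3 to compound 4 (within the scatter), so that compound 3 and compound 4 are not told apart: the same change on two cores in this assay, a number 12.8 percentage points lower (beyond the scatter) from compound 1 to compound 2 and a number 5.3 percentage points higher (within the scatter) from compound 3 to compound 4, 18.1 percentage points apart, beyond the scatter of two such steps

The same four compounds, read the other way, show methyl in place of hydrogen on an oxygen giving a number 12.1 percentage points higher from compound 2 to compound 4 (beyond the scatter), which also fails to match that change on the trifluoromethyl side: the same change on two cores in this assay, a number 6 percentage points lower (within the scatter) from compound 1 to compound 3 and a number 12.1 percentage points higher (beyond the scatter) from compound 2 to compound 4, 18.1 percentage points apart, beyond the scatter of two such steps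

These two comparisons are one non-additive result seen from two sides, not two independent findings; they show that the earlier step is no safe guide on the core of compound 3, but, with one pair per core and one concentration, they give neither a reason for the mismatch nor a rule for any other core.

Going by these compounds, whether the mismatch is specific to the chloro and trifluoromethyl pair stays open, as does how a fluoro or a nitrile would read in that place on the two cores. Also open, on these data alone, is whether the dependence on the core extends to an amine or a longer ether chain in place of the hydroxy or methyl ether oxygen substituent.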